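The source may report more compounds than this note shows. Statements on the series, on what has been measured and on what is new or still open speak of the compounds shown alone.

Working notes on the series.

Compound 1 `OCCC1CCN(c2nccnc2OC2CN(c3ccc4ccccc4n3)C2)CC1` is the anchor of the set. In a physicochemical assay for solubility, in phosphate buffer, at pH 7.4 (a higher number here means a more soluble compound, a lower number a less soluble compound), compound 1 gives 84000 nM, and that is the only number shown among the three measured compounds. Compound 2 `Cc1ccc(-c2nccnc2OC2CN(c3ccc4ccccc4n3)C2)cc1` returns a limit in this assay, < 1000 nM, not a number. Compound 3 `N#Cc1ccc(-c2nccnc2OC2CN(c3ccc4ccccc4n3)C2)cc1` likewise returns a limit in this assay, < 1000 nM. The steps from the anchor are an at least 84-fold lower number from compound 1 to compound 2 (1.92 log units; beyond the scatter) and an at least 84-fold lower number from compound 1 to compound 3 (1.92 log units; beyond the scatter); the step that the two limits leave unreadable from compound 2 to compound 3 cannot be sized, since both ends sit at the limit of < 1000 nM in this assay, at which 2 of the 3 values shown sit.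

Compound 4 `c1ccc(-c2nccnc2OC2CN(c3ccc4ccccc4n3)C2)nc1` is not yet measured. It differs from compound 1 in one place: pyridin-2-yl in place of 4-(2-hydroxyethyl)piperidin-1-yl on an aromatic carbon. Both measured steps away from compound 1 exchange the same group for an aryl ring and fall past the limit, so for compound 4 the expected step in this assay is a 70-fold lower number from compound 1 to compound 4 (1.85 log units; beyond the scatter), downward and large. The estimate for compound 4 in this assay is 1200 nM, with a range of 200 nM to 6000 nM, and a limit read-out is a real possibility.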

Compound 4, solubility: 349000 nM
For compound 4 the middle estimate is 290-fold (2.46 log units) below the measured one; the whole stated range lies below it.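

At this position, on an aromatic carbon next to the ring nitrogen, a six-membered aromatic ring does not by itself bring the number down in this assay: the exchange for pyridin-2-yl gives a 4.2-fold higher number from compound 1 to compound 4 (0.62 log units; beyond the scatter), opposite in direction to the two earlier exchanges to 4-methylphenyl and 4-cyanophenyl. Among the aromatic rings the differences are much larger, with an at least 340-fold higher number from compound 3 to compound 4 (2.54 log units; beyond the scatter) and an at least 340-fold higher number from compound 2 to compound 4 (2.54 log units; beyond the scatter). The full size of these last two steps stays unknown because compound 2 and compound 3 return limits, not numbers: the limit of < 1000 nM in this assay, at which 2 of the 4 values shown sit.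

The compounds shown leave open whether the rise belongs to the ring nitrogen of pyridin-2-yl or to the lack of a methyl or cyano group on that ring. Plain phenyl and pyridin-3-yl at this place would separate the two.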